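Acetyl for Methoxy on a Shared Fused Core

The source may hold more compounds than are shown below. What is called first, only, known or untested is meant among the compounds shown, and "the series" means these compounds.

Compound 1, `CC(C)c1cccc2nc(N3CCN(C)CC3)oc12`: in a functional assay on ileum (strain Hartley) for agonist activity at 5-hydroxytryptamine receptor 3A (Cavia porcellus) (on this read-out lower numbers stand for lower potency and higher numbers for higher potency (the scale is a negative logarithm)), compound 1 gives < 4, which is a limit of the assay and not a number.
Compound 2, `CN1CCN(c2nc3cccc(Cl)c3o2)CC1`: in this assay compound 2 gives 5.5.
Compound 3, `COc1ccc2oc(N3CCN(C)CC3)nc2c1`: in this assay compound 3 gives 4.78.

Among the compounds with values here, all three share one core and differ only in the single group attached to its six-membered aromatic ring of carbon only. Among the two numbers that are not limits, compound 3 stands lowest; the nearest value belongs to compound 2, which lies higher by a gap beyond the usual scatter. Within the data shown here, the only step between two measured compounds, a number at least 1.50 log units higher from compound 1 to compound 2 (beyond the scatter), concerns a different position and starts from the limit of < 4 in this assay, at which 1 of the 3 values shown sits, so it says nothing direct about the change followed here.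

Compound 4, `CC(=O)c1ccc2oc(N3CCN(C)CC3)nc2c1`, differs from compound 3 in one place: acetyl in place of methoxy on an aromatic carbon. Among the measured compounds shown here, no measured pair sets an acetyl against a methoxy, so the step of a number 0.02 log units higher from compound 3 to compound 4 (within the scatter) is expected to stay within the scatter. Compound 4 is therefore estimated at 4.8, between 4.2 and 5.4.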

Compound 4, negative logarithm of the half-maximal effective concentration: < 4
Compound 4 was reported as a limit; the forecaster's own chance of this, stated with the estimate: 20%; middle value at least 0.80 log units from the limit.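

Setting acetyl in place of methoxy on this aromatic carbon gives a number at least 0.78 log units lower from compound 3 to compound 4 (beyond the scatter) in this assay, so the group held at this position matters to the read-out, something the earlier compounds could not show, as no measured pair among them differed here. Compound 4 gives < 4, which is a limit of the assay and not a number. The step is therefore open-ended, and its full size cannot be read because it ends at a limit: the limit of < 4 in this assay, at which 2 of the 4 values shown sit.

From the compounds shown here alone, whether an amine, a carboxylic acid or a longer chain such as ethoxy on this same carbon would stay near compound 3 or drop as compound 4 does remains open. So does whether chloro or isopropyl would act here as they do at their own position in compound 2 and compound 1.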